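From a furan to a phenylethyl on the amine

The source may report more compounds than this note shows. Statements on the series, on what has been measured and on what is new or still open speak of the compounds shown alone.

Of the compounds shown here, three sharing one core have been measured in an assay on CHO cells for displacement of a labelled ligand from 5-hydroxytryptamine receptor 1D (Homo sapiens); a lower number here means a stronger inhibitor, a higher number a weaker inhibitor. Compound 1 `CN(Cc1cccs1)C1CCN(CCCc2c[nH]c3ccc(-n4cnnc4)cc23)CC1` gives 4.3 nM. Compound 2 `c1ccc2c(c1)CCC2NC1CCN(CCCc2c[nH]c3ccc(-n4cnnc4)cc23)CC1` gives 8.9 nM. Compound 3 `c1cc(CNC2CCN(CCCc3c[nH]c4ccc(-n5cnnc5)cc34)CC2)co1` gives 4.5 nM, the second highest of the three numbers; both steps that end at compound 3, namely a 1.0-fold higher number from compound 1 to compound 3 (0.02 log units; within the scatter) and a 2.0-fold lower number from compound 2 to compound 3 (0.30 log units; within the scatter), lie within the scatter, so no order among the three can be claimed. Compound 4 `C[C@@H](NC1CCN(CCCc2c[nH]c3ccc(-n4cnnc4)cc23)CC1)c1ccccc1` differs from compound 3 by one change: 1-phenylethyl in place of (furan-3-yl)methyl on an amine nitrogen. The step that bears most directly on this is a 2.0-fold lower number from compound 2 to compound 3 (0.30 log units; within the scatter), where one group on the same amine nitrogen was traded for another without a shift beyond the scatter, while a 2.1-fold higher number from compound 1 to compound 2 (0.32 log units; beyond the scatter) was only modest. Compound 4 is therefore expected to stay close to compound 3, with at most a small rise, a 1.3-fold higher number from compound 3 to compound 4 (0.12 log units; within the scatter). The estimate for compound 4 is 6 nM, with a range from 3 nM to 13 nM.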

Compound 4, half-maximal inhibitory concentration: 0.4 nM
Beside the measured number, compound 4's estimate is 15-fold (1.18 log units) above it, outside the stated range (below it).
By their numbers in this assay, from the lowest: compound 4; then compounds 1, 3 and 2 (each within the scatter of the next, the first and the last beyond it).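

In this assay, among these compounds, the amine nitrogen on the saturated ring carbon proves far more sensitive to its group than the earlier compounds suggested, since 1-phenylethyl in place of (furan-3-yl)methyl gives an 11-fold lower number from compound 3 to compound 4 (1.05 log units; beyond the scatter). The advantage of compound 4 also holds against the other two compounds, with a 22-fold lower number from compound 2 to compound 4 (1.35 log units; beyond the scatter) and an 11-fold lower number from compound 1 to compound 4 (1.03 log units; beyond the scatter), so it does not depend on a single comparison. A six-membered aromatic ring of carbon only is not enough by itself, as compound 2 also carries one within its 2,3-dihydro-1H-inden-1-yl group.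

A plain benzyl group and the opposite stereoisomer of 1-phenylethyl on this nitrogen would show whether the branching methyl or the defined stereocentre matters for this result. No measurement presented here explains the gain.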